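A few compounds are considered here, and "the series" means these few. Any claim that something is new, unique, unknown or untested is made for them only; others in the source may bear on it.

Of the compounds shown here, three that share a common core have so far been tested in an assay on CHO-K1 cells for displacement of a labelled ligand from adenosine receptor A1 (Homo sapiens), with a stated time of 2 h; a higher number here means a weaker inhibitor, a lower number a stronger inhibitor. Compound 1 `COCCCNC(=O)COc1ccc2c(c1)c(CCc1ccccc1)c(-c1ccc(F)cc1F)c(=O)n2C` gives 3620 nM. Compound 3 `CN(Cc1ccc(Cl)c(Cl)c1)C(=O)COc1ccc2[nH]c(=O)c(S(C)(=O)=O)c(CCc3ccccc3)c2c1` gives 602 nM. Compound 2 `CC(C)(NC(=O)NCc1ccc2[nH]c(=O)c(-c3nccs3)c(CCc3ccccc3)c2c1)c1ccccc1` gives 68 nM, the lowest of the three numbers and therefore the strongest binder in this small set; its nearest neighbour is compound 3 and its furthest is compound 1, and both of those gaps lie beyond the usual scatter of this assay.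

The next step leads from compound 2 to compound 4 `O=C(CCc1ccccc1)NCc1ccc2[nH]c(=O)c(-c3nccs3)c(CCc3ccccc3)c2c1`, which has not yet been measured. The structural change is phenethyl in place of (1-methyl-1-phenylethyl)amino on a carbonyl carbon, or, cut one bond further out, (1-methyl-1-phenylethyl)carbamoyl to phenethylcarbonyl. Among the compounds with values here, no measured pair in this set makes the same change, so the size of the step cannot be read off directly. Because compound 2 sits at 68 nM while the other two compounds lie well above it, a loss of binding is judged more likely than a further gain. Compound 4 is therefore expected to give about 220 nM, within a range from 60 nM to 800 nM. That estimate amounts to an expected step from compound 2 to compound 4 of a 3.2-fold higher number from compound 2 to compound 4 (0.51 log units; beyond the scatter), a moderate weakening beyond the scatter.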

Compound 4, inhibition constant: 3250 nM
Compound 4: middle estimate off by 15-fold (1.17 log units), on the low side; measured number outside the range, above it.
By their numbers in this assay, from the lowest: compound 2; then compound 3; then compounds 4 and 1 (each within the scatter of the next).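

Swapping (1-methyl-1-phenylethyl)amino for phenethyl on a carbonyl carbon gives a 48-fold higher number from compound 2 to compound 4 (1.68 log units; beyond the scatter) in this assay, the first single-place change in this set, and it shows that binding is highly sensitive to the group at this position while the rest of the molecule stays the same. Both groups carry one six-membered aromatic ring of carbon only and no net charge, yet keeping that ring does not preserve the binding; the groups differ in that the one leaving has a nitrogen with a hydrogen-bond donor and a branched carbon, and the one entering has neither. Nothing measured here explains the loss.

This one step changes the nitrogen and the branching together, so the compounds shown cannot say which of the two matters, or whether both do. A phenethylamino group on the same carbonyl carbon would keep the nitrogen without the branching, while a 1-methyl-1-phenylethyl group joined directly to the carbonyl carbon through a methylene would keep the branching without the nitrogen.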